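This account rests on a few compounds, and the source may have more. Where it says the series, first, only, none or still open, it means among the compounds named here.

In a physicochemical assay for solubility, read by HPLC, in phosphate buffer, with a stated time of 24 h, at pH 6.5 (on this read-out higher numbers stand for higher solubility and lower numbers for lower solubility), compound 2 `CCCS(=O)(=O)Nc1ccc(F)c(C(=O)Nc2cnc3[nH]nc(C)c3c2)c1F` gives 380 ug/mL and compound 3 `CCCS(=O)(=O)Nc1ccc(F)c(C(=O)Nc2cnc3[nH]nc(N(C)C)c3c2)c1F` gives 290 ug/mL, so the two stand level within the scatter. Compound 1 `CCCS(=O)(=O)Nc1ccc(Cl)c(C(=O)Nc2cnc3[nH]nc(OC)c3c2)c1F` also bears methoxy but differs from compound 4 elsewhere in the structure. Compound 1 reports only a limit, < 1 ug/mL. Compound 3 therefore sits with compound 2 among the two true numbers in the set.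

Compound 4 `CCCS(=O)(=O)Nc1ccc(F)c(C(=O)Nc2cnc3[nH]nc(OC)c3c2)c1F` carries methoxy in place of dimethylamino on an aromatic carbon, the change being (methoxy in place of dimethylamino on an aromatic carbon). Two pieces of evidence bear on it. Among the compounds with values here, the one measured step that involves dimethylamino is a 1.3-fold lower number from compound 2 to compound 3 (0.12 log units; within the scatter), and it gives no sign of a large shift. Within the data shown here, compound 1 at < 1 ug/mL is the only measured compound with methoxy, but it is an imperfect guide to compound 4, and it serves here only as a caution on the low side.

Taken together, these point to a moderate fall in this assay, with wide uncertainty. The expected step is a 2.9-fold lower number from compound 3 to compound 4 (0.46 log units; beyond the scatter). For compound 4 the estimate is 100 ug/mL, with an expected range from 5 ug/mL to 400 ug/mL.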

Compound 4, solubility: 4 ug/mL
The estimate for compound 4 lay 25-fold (1.40 log units) above the measured number; the whole stated range lies above it.
By their numbers in this assay, from the lowest: compound 4; then compounds 3 and 2 (each within the scatter of the next). At a limit, below all of these: compound 1.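

In this assay, this carbon of the five-membered aromatic ring proves highly sensitive to the group it carries: methyl and dimethylamino had stood level, yet methoxy gives a 73-fold lower number from compound 3 to compound 4 (1.86 log units; beyond the scatter) and a 95-fold lower number from compound 2 to compound 4 (1.98 log units; beyond the scatter). Dimethylamino and methoxy match in hydrogen-bond donors, hydrogen-bond acceptors and net charge, so these counts do not separate the large step from compound 3 to compound 4. With methoxy held, fluoro in place of chloro on an aromatic carbon gives an at least 4.0-fold higher number from compound 1 to compound 4 (0.60 log units; beyond the scatter), so both methoxy compounds lie low in the set, though this step starts from a limit rather than a number: the limit of < 1 ug/mL in this assay, at which 1 of the 4 values shown sits.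

The compounds shown cannot tell what lies behind the fall, and it remains open how ethoxy, a hydroxyl group or a primary amine would read at this carbon. Also open, going by these compounds, is whether exchanging methyl or dimethylamino for methoxy would bring a step of similar size in the chloro series, where compound 1 offers a limit only.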